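This account rests on a few compounds, and the source may have more. Where it says the series, first, only, none or still open, it means among the compounds named here.

Measured compounds in the series so far:

- compound 1, `COc1ccc(CS(=O)(=O)/C=C/c2c(OC)cccc2OC)cc1[N+](=O)[O-]`: > 30000 nM
- compound 2, `COc1cc(/C=C/S(=O)(=O)Cc2ccc(OC)c([N+](=O)[O-])c2)cc(OC)c1`: > 30000 nM
- compound 3, `COc1ccc(CS(=O)(=O)/C=C/c2c(OC)cccc2OC)cc1N`: 17100 nM

All three were run in an ADME assay on MRC5 cells (Homo sapiens) for cytotoxicity, read by MTT assay, with a stated time of 72 h; on this read-out lower numbers stand for stronger inhibition of growth and higher numbers for weaker inhibition of growth. For compound 1 the reading is a limit of the assay, not a number. For compound 2 the reading is likewise a limit. Compound 3 alone gives a numeric value.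

Compound 1 and compound 3 differ in one place: amino in place of nitro on an aromatic carbon. The step is an at least 1.7-fold lower number from compound 1 to compound 3 (0.24 log units; that floor lies within the scatter). It is a floor rather than a measured size because compound 1 sits at the limit of > 30000 nM in this assay, at which 2 of the 3 values shown sit.

Compound 1 and compound 2 are built from the same atoms joined differently; the difference between the two cores is not broken down here.

Compound 4, `COc1cc(/C=C/S(=O)(=O)Cc2ccc(OC)c(N)c2)cc(OC)c1`, is still to be measured. It stands to compound 2 as compound 3 stands to compound 1: amino in place of nitro on an aromatic carbon. The surroundings of the place are described in the same words for both pairs, so this is the same change made on the other core.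

Going by the values given here, the only guide is the pair of compound 1 and compound 3, whose step is an at least 1.7-fold lower number from compound 1 to compound 3 (0.24 log units; that floor lies within the scatter). On that basis the step from compound 2 to compound 4 in this assay is expected to be an at least 1.5-fold lower number from compound 2 to compound 4 (0.17 log units; that floor lies within the scatter). Compound 4 is accordingly estimated at 20000 nM, with a likely range from 8000 nM to 50000 nM, and a real chance that only a limit is reported.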

Compound 4, concentration for 50% growth inhibition: > 30000 nM
Compound 4: a limit, no number; the forecaster's own chance of this, stated with the estimate: 40%; at least 1.5-fold (0.17 log units) between middle value and limit.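

Going by these compounds alone, compound 2 and compound 4 both stand as limits of the assay, not numbers, so no step between the two can be read: the limit of > 30000 nM in this assay, at which 3 of the 4 values shown sit. The compounds shown leave open whether amino in place of nitro on an aromatic carbon changes the number at all on the core of compound 2, and how any such change compares with that on the core of compound 1.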